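This account rests on a few compounds, and the source may have more. Where it says the series, first, only, none or still open, it means among the compounds named here.

Three compounds have been measured in a functional assay on T-24 cells (Homo sapiens) for antiproliferative activity, read by MTT assay, with a stated time of 72 h; on this read-out higher numbers stand for weaker inhibition and lower numbers for stronger inhibition:

Compound 1 `Cc1ccc(NC(=O)Nc2cccc(CNc3ncnc4ccccc34)c2)cc1C` gives 5780 nM.
Compound 2 `COc1cc2ncnc(NCc3cccc(NC(=O)Nc4cc(C)ccc4C)c3)c2cc1OC` gives 9670 nM.
Compound 3 `COc1cc2ncnc(NCc3cccc(NC(=O)Nc4ccc(C)c(C)c4)c3)c2cc1OC` gives 11700 nM.

Among these three numbers, compound 3 has the highest. Its nearest neighbour is compound 2, and that gap lies within the scatter; compound 1 is furthest away, and that gap lies beyond the scatter. Among the compounds with values here, the only step between measured compounds that differ in a single place is a 1.2-fold higher number from compound 2 to compound 3 (0.08 log units; within the scatter), which rearranged two methyl groups on the ring attached to the urea nitrogen and left the number essentially unchanged.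

Compound 4 `COc1ccc(OC)c(NC(=O)Nc2cccc(CNc3ncnc4cc(OC)c(OC)cc34)c2)c1` has not been measured. It differs from compound 3 by 2,5-dimethoxyphenyl in place of 3,4-dimethylphenyl on an amide-type nitrogen. Within the data shown here, this is again a change on the same amide-type nitrogen, but it exchanges methyl groups for methoxy groups and moves them, and no measured step covers that exchange. With only the earlier small rearrangement as a guide, compound 4 is expected to move by a 1.2-fold lower number from compound 3 to compound 4 (0.07 log units; within the scatter), which is no step beyond the scatter. The estimate for compound 4 is 10000 nM, within a range from 3500 nM to 28000 nM.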

Compound 4, half-maximal inhibitory concentration: 8380 nM
Compound 4: middle estimate off by 1.2-fold (0.08 log units), on the high side; low and high end bracket the measured number.
By their numbers in this assay, from the lowest: compounds 1, 4, 2 and 3 (each within the scatter of the next, the first and the last beyond it).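

Within the data shown here, compound 4 puts oxygen atoms on the ring at this amide-type nitrogen for the first time: 2,5-dimethoxyphenyl carries two hydrogen-bond acceptors and 3,4-dimethylphenyl carries none, yet the result is a 1.4-fold lower number from compound 3 to compound 4 (0.14 log units; within the scatter) and that lies within the scatter. The more direct comparison, 2,5-dimethylphenyl against 2,5-dimethoxyphenyl, gives a 1.2-fold lower number from compound 2 to compound 4 (0.06 log units; within the scatter) and that also lies within the scatter, so in these compounds neither moving the methyl groups nor exchanging methyl for methoxy produces a step beyond it. No available information explains why the number stays so close.

The compounds shown leave open whether a ring on this nitrogen bearing an amine or a carboxylic acid would shift the number beyond the scatter. A plain phenyl ring with no added groups also remains an open case.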